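This account rests on a few compounds, and the source may have more. Where it says the series, first, only, none or still open, it means among the compounds named here.

Compound 1 `C=C1C[C@]23C[C@@]1(O)CC[C@H]2c1ccc(O)c(C)c1[C@@H]3Cn1cc(-c2ccc(C(F)(F)F)cc2)nn1`: in a functional assay on SMMC-7721 cells (Homo sapiens) for cytotoxicity, read by MTT assay, with a stated time of 4 days (a higher number here means a weaker inhibitor, a lower number a stronger inhibitor), compound 1 gives > 20000 nM, which is a limit of the assay and not a number.
Compound 2 `C=C1C[C@]23C[C@@]1(O)CC[C@H]2c1cc(Br)c(O)c(C)c1[C@@H]3Cn1cc(-c2ccc(OC)cc2)nn1`: in this assay compound 2 gives > 20000 nM, again a limit.
Compound 3 `C=C1C[C@]23C[C@@]1(O)CC[C@H]2c1cc(Br)c(O)c(C)c1[C@@H]3Cn1cc(-c2ccc(F)cc2)nn1`: in this assay compound 3 gives > 20000 nM, also a limit.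

Compound 3 thus stands at the upper boundary of what this assay can report, and every value shown sits there too (the limit of > 20000 nM in this assay, at which 3 of the 3 values shown sit). The unmeasured compound 4 `C=C1C[C@]23C[C@@]1(O)CC[C@H]2c1cc(Br)c(O)c(C)c1[C@@H]3Cn1cc(-c2ccc(C(F)(F)F)cc2)nn1` differs from it by trifluoromethyl in place of fluoro on an aromatic carbon. Among the compounds with values here, only one measured step touches this position, the step from compound 2 to compound 3 a step that the two limits leave unreadable from compound 2 to compound 3, and its size cannot be read because both ends are limits. Compound 1 carries the same trifluoromethyl group on a core lacking bromine and likewise sits at the limit. With no readable step and every neighbour at the boundary, no shift beyond the scatter is expected in this assay; the step from compound 3 to compound 4 is estimated as a step that the limit leaves unreadable from compound 3 to compound 4. Compound 4 is therefore expected to give about 30000 nM, between 10000 nM and 100000 nM, most likely reported as a limit.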

Compound 4, half-maximal inhibitory concentration: 12800 nM
The estimate for compound 4 lay 2.3-fold (0.37 log units) above the measured number; measured number inside the range.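

In this assay compound 4 is the first compound shown to give a number rather than a limit, so a readable result appears where trifluoromethyl on this aromatic carbon and bromo on the core stand together. Trifluoromethyl in place of fluoro gives an at least 1.5-fold lower number from compound 3 to compound 4 (0.19 log units; that floor lies within the scatter), trifluoromethyl in place of methoxy gives an at least 1.5-fold lower number from compound 2 to compound 4 (0.19 log units; that floor lies within the scatter), and bromo in place of hydrogen gives an at least 1.5-fold lower number from compound 1 to compound 4 (0.19 log units; that floor lies within the scatter). These are only floors and not full sizes, because the other end of each step is a limit: the limit of > 20000 nM in this assay, at which 3 of the 4 values shown sit.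

Going by these compounds, how large the three steps truly are stays open, as the values of compound 1, compound 2 and compound 3 are not known beyond their limits. Also open, on these data alone, is what an amine, a carboxylic acid or a longer chain on this aromatic carbon would give.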